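A few compounds are considered here, and "the series" means these few. Any claim that something is new, unique, unknown or untested is made for them only; others in the source may bear on it.

Compound 1 `O=C(Nc1cccc(-n2cc(-c3ccncc3)c(-c3cc(O)cc(Cl)c3)n2)c1)Nc1ccc(Cl)c(C(F)(F)F)c1` and compound 2 `COc1cc(Cl)cc(-c2nn(-c3cccc(NC(=O)Nc4ccc(Cl)c(C(F)(F)F)c4)c3)cc2-c2ccncc2)c1` share a core and differ in one spot: methyl in place of hydrogen on an oxygen on an aromatic ring. In a functional assay on HCT-116 cells (Homo sapiens) for inhibition, read by sulforhodamine B assay, with a stated time of 48 h, tested at 10 uM (a higher number here means a weaker effect of the compound at the concentration tested, a lower number a stronger effect), compound 1 gives 6.95% and compound 2 gives 3.39%, so the step of a number 3.6 percentage points lower from compound 1 to compound 2 (within the scatter) is small. Compound 3 `O=C(Nc1cccc(-n2cc(-c3ccncc3)c(-c3cc(O)cc(Cl)c3)n2)c1)c1cc(C(F)(F)F)cc(C(F)(F)F)c1` keeps the hydroxy of compound 1 but has a different core; the difference between the two cores is not broken down here. In this assay compound 3 gives 24.6%, the highest number of the three. Compound 4 `COc1cc(Cl)cc(-c2nn(-c3cccc(NC(=O)c4cc(C(F)(F)F)cc(C(F)(F)F)c4)c3)cc2-c2ccncc2)c1` is related to compound 3 by the same change, (methyl in place of hydrogen on an oxygen on an aromatic ring), with the place described in identical words. Because the earlier step of a number 3.6 percentage points lower from compound 1 to compound 2 (within the scatter) stayed within the scatter, compound 4 is expected to sit close to compound 3, a step of a number 3.6 percentage points lower from compound 3 to compound 4 (within the scatter). Compound 4 is thus estimated at 21%, plausibly between 8% and 36%.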

Compound 4, a percentage reported as activity, at one concentration (the size of the read-out at that concentration, not a potency): 35.2%
For compound 4 the middle estimate is 14.2 percentage points below the measured one; the measured number falls inside the stated range.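

Replacing hydroxy with methoxy does not have the same effect on both cores in this assay: the same change on two cores in this assay, a number 3.6 percentage points lower (within the scatter) from compound 1 to compound 2 and a number 10.6 percentage points higher (beyond the scatter) from compound 3 to compound 4, 14.2 percentage points apart, beyond the scatter of two such steps. On the core of compound 3, the change gives a number 10.6 percentage points higher from compound 3 to compound 4 (beyond the scatter), so the small step on the core of compound 1 was no safe guide to the size of the step on another core. These two pairs show that the result of this change can depend on the core, but they do not show why, or what the change would do on any further core.

From the compounds shown here alone, what an ethoxy group or an amine in the same place would do on either core stays open. Each number also comes from a single concentration, so it tells only how strong or weak the effect of each compound is at that concentration.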